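From chloro to methyl on a shared core

The compounds below may be only part of what the source reports. "The series", "measured", "known", "first", "only" and "open" are said of these compounds alone.

Measured compounds:
compound 1 `CCC(O)CNC(=O)/C=C/c1cccc(C(F)(F)F)c1` with 92.9 mg/kg
compound 2 `CN1C(=O)CCC1(O)c1cccc(C(F)(F)F)c1` with 133 mg/kg
compound 3 `CN1C(=O)CCC1(O)c1cccc(Cl)c1` with > 200 mg/kg

In a functional assay on the whole organism with Mus musculus as the target (on this read-out lower numbers stand for an effect already at smaller amounts and higher numbers for an effect only at larger amounts of compound), compound 3 gives > 200 mg/kg as a limit and not a number. Compound 4 `Cc1cccc(C2(O)CCC(=O)N2C)c1` carries methyl in place of chloro on an aromatic carbon. The step of an at least 1.5-fold higher number from compound 2 to compound 3 (0.17 log units; that floor lies within the scatter) is the only measured one at this place, and it is itself bounded by that limit. Compound 1 has a different core and does not bear on the change. No step beyond the scatter is therefore expected in this assay and a further limit is quite possible. The expected step is a step that the limit leaves unreadable from compound 3 to compound 4 on this estimate. Compound 4 is estimated at 220 mg/kg (range 120 mg/kg to 400 mg/kg).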

Compound 4, dose for half-maximal effect: 138 mg/kg
Beside the measured number, compound 4's estimate is 1.6-fold (0.20 log units) above it, and the stated range covers the measured number.
By their numbers in this assay, from the lowest: compounds 1, 2 and 4 (each within the scatter of the next). At a limit, above all of these: compound 3.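

In this assay the methyl group on this aromatic carbon gives a number where chloro gave only a limit, and the change from chloro to methyl reads as an at least 1.4-fold lower number from compound 3 to compound 4 (0.16 log units; that floor lies within the scatter) as a floor only. The change from trifluoromethyl to methyl gives a 1.0-fold higher number from compound 2 to compound 4 (0.02 log units; within the scatter) and so does not separate these two groups at this place. The value of compound 3 remains a limit and not a number: the limit of > 200 mg/kg in this assay, at which 1 of the 4 values shown sits.

Going by these compounds, how far chloro truly lies from methyl stays open. So does how an amine or a carboxylic acid would read at this place on the shared core.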